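The compounds below may be only part of what the source reports. "The series", "measured", "known", "first", "only" and "open" are said of these compounds alone.

In an assay on isolated protein for inhibition of ubiquitin carboxyl-terminal hydrolase 7 (Homo sapiens), with stated times of 30 min and 2 h (on this read-out higher numbers stand for weaker inhibition and lower numbers for stronger inhibition), compound 3 `Cn1nc2c(=O)n(CC3(O)CCN(Cc4ccc(C5CCCO5)cc4Cl)CC3)cnc2c1-c1ccc(CN)cc1` gives 3820 nM and stands with the highest number of the three measured compounds, that is, as the weakest inhibitor among them. Compound 1 `Cc1ccc(-c2ccc(CN3CCC(O)(Cn4cnc5c(-c6ccc(CN)cc6)n(C)nc5c4=O)CC3)c(Cl)c2)s1` gives 101 nM, and compound 2 `Cn1nc2c(=O)n(CC3(O)CCN(Cc4ccc(-c5ccco5)cc4Cl)CC3)cnc2c1-c1ccc(CN)cc1` gives 18.1 nM. Compound 4 `Cn1nc2c(=O)n(CC3(O)CCN(Cc4ccc(-n5ccnc5)cc4Cl)CC3)cnc2c1-c1ccc(CN)cc1` has not yet been measured; it differs from compound 3 in one place: 1H-imidazol-1-yl in place of oxolan-2-yl on an aromatic carbon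

The measured steps that bear on this change are those that swap the oxolan-2-yl group for a five-membered aromatic ring. There was a 38-fold higher number from compound 1 to compound 3 (1.58 log units; beyond the scatter) and a 210-fold higher number from compound 2 to compound 3 (2.32 log units; beyond the scatter), so moving from the non-aromatic oxolan-2-yl to an aromatic five-membered ring has twice gone with a large move toward stronger inhibition. The 1H-imidazol-1-yl group is also a five-membered aromatic ring, so a large drop in the number is expected, though whether it reaches the level of compound 2 is uncertain. Compound 4 is therefore expected to show a 55-fold lower number from compound 3 to compound 4 (1.74 log units; beyond the scatter), giving an estimate of 70 nM with a range from 15 nM to 350 nM.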

Compound 4, half-maximal inhibitory concentration: 228 nM
Beside the measured number, compound 4's estimate is 3.3-fold (0.51 log units) below it; low and high end bracket the measured number.
By their numbers in this assay, from the lowest: compound 2; then compound 1; then compound 4; then compound 3.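

In this assay, a third five-membered aromatic ring at this place, para to a large group, again improves on oxolan-2-yl, with a 17-fold lower number from compound 3 to compound 4 (1.22 log units; beyond the scatter) so the gain does not belong to furan-2-yl and 5-methylthiophen-2-yl alone. The aromatic rings are not interchangeable, however: there is a 13-fold higher number from compound 2 to compound 4 (1.10 log units; beyond the scatter) and a 2.3-fold higher number from compound 1 to compound 4 (0.35 log units; beyond the scatter) so the identity of the ring matters as well as its being aromatic. Nothing measured here speaks to the reason for these differences.

The compounds shown leave open whether the gap to furan-2-yl follows from joining the ring through nitrogen rather than carbon, which a 1H-imidazol-2-yl group would test directly. They also leave open how a six-membered ring such as pyridin-3-yl or an open chain such as methoxyethyl would compare here.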